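Replacing a hydroxyl-bearing benzamide in an inactive thiosulfate sulfurtransferase series

The source may hold more compounds than are shown below. What is called first, only, known or untested is meant among the compounds shown, and "the series" means these compounds.

Compounds measured so far:
compound 1, `O=C(Nc1ccc(Sc2nc3ccccc3s2)c(Cl)c1)c1cccc(Br)c1O`, > 100000 nM
compound 2, `O=C(Nc1ccc(Sc2nc3ccccc3s2)cc1)c1cccc(Br)c1O`, > 100000 nM
compound 3, `O=C(Nc1ccccc1)c1cccc(Br)c1O`, > 100000 nM

In an assay on isolated protein for inhibition of thiosulfate sulfurtransferase (Homo sapiens), with a stated time of 60 min, in the absence of a further agent (a higher number here means a weaker inhibitor, a lower number a stronger inhibitor), compound 1 reaches only the limit of the assay, > 100000 nM, not a number. Compound 2 likewise sits at the limit, > 100000 nM. Compound 3 also sits at the limit, > 100000 nM. Among the measured compounds shown here, the single step between measured compounds, a step that the two limits leave unreadable from compound 1 to compound 2, is therefore unreadable; all three values share (the limit of > 100000 nM in this assay, at which 3 of the 3 values shown sit).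

Compound 4, `COc1ccc(Br)cc1C(=O)Nc1ccc(Sc2nc3ccccc3s2)c(Cl)c1`, differs from compound 1 by 5-bromo-2-methoxyphenyl in place of 3-bromo-2-hydroxyphenyl on a carbonyl carbon. For the measured compounds named here, no measured step reaches a number, so no direction can be drawn from them. Compound 4 is expected to stay at the limit, with a step that the limit leaves unreadable from compound 1 to compound 4 that is only nominal, giving an estimated 150000 nM in this assay, between 50000 nM and 1000000 nM.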

Compound 4, half-maximal inhibitory concentration: > 100000 nM
Compound 4 ended at the assay's limit; the forecaster's own chance of this, stated with the estimate: 85%; the middle value lies beyond the limit too.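

Compound 4 gives > 100000 nM as a limit of the assay and not a number, so no step from compound 1 to compound 4 can be read: the limit of > 100000 nM in this assay, at which 4 of the 4 values shown sit.

From the compounds shown here alone, whether any change to these compounds can give a readable number in this assay stays open.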